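A few compounds are considered here, and "the series" means these few. Any claim that something is new, unique, unknown or untested is made for them only; others in the source may bear on it.

In a functional assay on J774 cells (Mus musculus) for cytotoxicity, read by resazurin assay, with a stated time of 72 h (on this read-out lower numbers stand for stronger inhibition and higher numbers for weaker inhibition), compound 3 `O=S(=O)(Nc1cccc(CO)c1)c1ccc(-c2ccc(Br)cc2F)cc1` gives 1000 nM, level at the digits shown with compound 1 `O=S(=O)(Nc1cc(CO)ccc1O)c1ccc(-c2ccc(Br)cc2)cc1`, which gives 1000 nM, a gap that sits within the usual scatter. Compound 2 `O=S(=O)(Nc1ccc(-c2ccc(Cl)cc2Cl)cc1)c1cccc(CO)c1` reaches only (the limit of > 10000 nM in this assay, at which 1 of the 3 values shown sits), and in this assay compound 2 is reported as > 10000 nM. Compound 4 `O=S(=O)(Nc1cccc(CO)c1)c1ccc(-c2ccc(Cl)cc2F)cc1` differs from compound 3 by chloro in place of bromo on an aromatic carbon, the 4-bromo-2-fluorophenyl group becoming 4-chloro-2-fluorophenyl. For the measured compounds named here, no measured pair in this set shows that change, so its size is not known from the data. The step that the estimate means, a 1.5-fold higher number from compound 3 to compound 4 (0.18 log units; within the scatter), is expected to stay within the scatter in either direction. Compound 4 is therefore estimated at 1500 nM in this assay, with a range from 500 nM to 5000 nM.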

Compound 4, half-maximal inhibitory concentration: 700 nM
Compound 4: the middle estimate sits 2.1-fold (0.33 log units) above what was measured; the measured number falls inside the stated range.
By their numbers in this assay, from the lowest: compounds 4, 1 and 3 (each within the scatter of the next). At a limit, above all of these: compound 2.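

On this aromatic carbon, para to a large group and meta to a fluoro group, putting chloro in place of bromo gives in this assay a 1.4-fold lower number from compound 3 to compound 4 (0.15 log units; within the scatter) and so does not move the number beyond the scatter. This is the only pair shown that differs in one place, and it shows that either of these two halogens can sit here with the same reading. Nothing measured here gives a reason for this step.

On these data alone, whether an amine, a carboxylic acid or a longer chain at this carbon would shift the number remains open. So does whether the same exchange would read alike without the fluoro group.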